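The compounds below may be only part of what the source reports. "The series", "measured", "known", "first", "only" and "open" are said of these compounds alone.

Compound 1 `CCn1c(C(=O)NCC(=O)OC)ccc1C(CC)(CC)c1ccc(OCS(=O)(=O)c2ccccc2)c(C)c1` is the stronger of the two numbers in hand: in a functional assay on BXPC-3 cells (Homo sapiens) for antiproliferative activity, read by MTT assay, with a stated time of 24 h (on this read-out lower numbers stand for stronger inhibition and higher numbers for weaker inhibition), compound 1 gives 20000 nM. Compound 3 `CCn1c(C(=O)NCCCO)ccc1C(CC)(CC)c1ccc(OCS(=O)(=O)c2ccccc2)c(C)c1` gives 26600 nM in this assay, a step of a 1.3-fold higher number from compound 1 to compound 3 (0.12 log units; within the scatter). Compound 2 `CCn1c(C(=O)N[C@H](C)C(=O)OC)ccc1C(CC)(CC)c1ccc(OCS(=O)(=O)c2ccccc2)c(C)c1` reaches only a limit in this assay, > 50000 nM, the one case of the limit of > 50000 nM in this assay, at which 1 of the 3 values shown sits. Its step from compound 1 is an at least 2.5-fold higher number from compound 1 to compound 2 (0.39 log units; beyond the scatter), while compound 2 to compound 3 is an at least 1.8-fold lower number from compound 2 to compound 3 (0.27 log units; that floor lies within the scatter).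

Compound 4 `CCn1c(C(=O)NCC(=O)O)ccc1C(CC)(CC)c1ccc(OCS(=O)(=O)c2ccccc2)c(C)c1` differs from compound 1 by hydrogen in place of methyl on an oxygen next to a carbonyl group. Going by the values given here, no measured step changes the ester itself; the amide-side changes in hand were either within the scatter or a modest loss. Compound 4 is therefore expected near compound 1, a 1.3-fold higher number from compound 1 to compound 4 (0.10 log units; within the scatter), estimated at 25000 nM within 10000 nM to 60000 nM.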

Compound 4, half-maximal inhibitory concentration: > 50000 nM
Compound 4: only a limit was reported (the forecaster's own chance of this, stated with the estimate: 35%); at least 2.0-fold (0.30 log units) between middle value and limit.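

In this assay, going by these compounds alone, the ester oxygen itself is changed for the first time, and hydrogen in place of methyl gives an at least 2.5-fold higher number from compound 1 to compound 4 (0.39 log units; beyond the scatter) as a real loss. The comparison with the hydroxy-ended amide gives an at least 1.8-fold higher number from compound 3 to compound 4 (0.27 log units; that floor lies within the scatter) and settles no order, since that floor lies within the scatter. Compound 4 is a limit and joins compound 2 there, so the step between them cannot be read: the limit of > 50000 nM in this assay, at which 2 of the 4 values shown sit.

Still open, as far as these compounds go, is how an ethyl ester, a primary amide or a longer chain ending in a carboxylic acid would read at this position.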